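The source may report more compounds than this note shows. Statements on the series, on what has been measured and on what is new or still open speak of the compounds shown alone.

Compound 1 `Cc1cc(Cl)ccc1NC(=O)Nc1nc(Sc2c[nH]c3ccccc23)cc(N2CCN(Cc3ccccc3)CC2)n1` is one of three closely related compounds tested in a functional assay on A549 cells (Homo sapiens) for inhibition, with a stated time of 72 h; a lower number here means a stronger inhibitor, a higher number a weaker inhibitor. In this assay compound 1 gives > 50000 nM, which is a limit of the assay rather than a number. Compound 2 `Cc1ccc(C)c(NC(=O)Nc2nc(Sc3c[nH]c4ccccc34)cc(N3CCN(Cc4ccccc4)CC3)n2)c1` differs from it only in the group on the amide-type nitrogen, and in this assay compound 2 gives > 50000 nM, again a limit. Compound 3 `COc1ccc(NC(=O)Nc2nc(Sc3c[nH]c4ccccc34)cc(N3CCN(Cc4ccccc4)CC3)n2)cc1` gives 42300 nM in this assay. The step that the two limits leave unreadable from compound 1 to compound 2 cannot be read, and the steps of an at least 1.1-fold lower number from compound 1 to compound 3 (0.07 log units; that floor lies within the scatter) and an at least 1.1-fold lower number from compound 2 to compound 3 (0.07 log units; that floor lies within the scatter) lie within the scatter, so compound 1 stands with the other two at the weak end, and none of the three is clearly set apart, as the limit of > 50000 nM in this assay, at which 2 of the 3 values shown sit, shows.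

Compound 4 `Cc1cc(Cl)ccc1NC(=O)Nc1nc(Sc2c[nH]c3ccccc23)cc(N2CCN(c3ccccn3)CC2)n1` keeps the whole urea side of compound 1 and changes a different part: pyridin-2-yl in place of benzyl on an amine nitrogen in a ring. Among the compounds with values here, none of the measured steps touches this position; all three swap the group on the amide-type nitrogen. Within the data shown here, no measured step therefore gives a direction for this change, and the expectation rests only on the shared core having stayed weak across compound 1, compound 2 and compound 3. Compound 4 is expected to give 50000 nM, within 20000 nM to 150000 nM, in this assay. This estimate means a step of a number no higher from compound 1 to compound 4 (the limit leaves the size open), expected to stay within the scatter.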

Compound 4, half-maximal inhibitory concentration: > 50000 nM
Compound 4 gave a limit, no number (the forecaster's own chance of this, stated with the estimate: 70%); the middle value sits exactly at the limit.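

In this assay compound 4 gives > 50000 nM, which is a limit and not a number. Compound 1 also gives only a limit, so the step between compound 1 and compound 4 cannot be read: the limit of > 50000 nM in this assay, at which 3 of the 4 values shown sit. The compounds shown leave open how far pyridin-2-yl in place of benzyl moves the number, if at all.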